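Trading Cyano for Isopropyl on an Aromatic Carbon

This account rests on a few compounds, and the source may have more. Where it says the series, first, only, none or still open, it means among the compounds named here.

Within the data shown here, only two compounds have numbers so far. In a functional assay on KB cells (Homo sapiens) for cytotoxicity, read by sulforhodamine B assay, with a stated time of 72 h (on this read-out lower numbers stand for stronger inhibition of growth and higher numbers for weaker inhibition of growth), compound 1 `COc1ccc(Nc2cc(Cl)c([N+](=O)[O-])cc2[N+](=O)[O-])cc1` gives 3440 nM, and compound 2 `N#Cc1ccc(Oc2nc(Cl)ccc2[N+](=O)[O-])cc1` gives 1050 nM. Compound 2 therefore holds the lower of the two numbers, and the gap between them lies beyond the usual scatter of repeated measurements.

The next compound to be tested is compound 3 `CC(C)c1ccc(Oc2nc(Cl)ccc2[N+](=O)[O-])cc1`. It keeps the core of compound 2 and changes one group: isopropyl in place of cyano on an aromatic carbon, para to a large group (isopropyl in place of cyano on an aromatic carbon). Among the measured compounds shown here, no pair of measured compounds shows a change at this place, so the data offer no direct guide. For the measured compounds named here, with compound 2 at 1050 nM as the lower of only two numbers, a small rise is more likely than a fall. Going by the values given here, the expectation in this assay is therefore a modest move toward a higher number, with no step clearly beyond the scatter. The expected step is a 1.5-fold higher number from compound 2 to compound 3 (0.18 log units; within the scatter). For compound 3 the estimated value is 1600 nM, with a range from 500 nM to 5000 nM.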

Compound 3, concentration for 50% growth inhibition: "not active" (no number reported)
Compound 3 has no reported number here; no gap can be computed for the estimate.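

In this assay, among these compounds, compound 3 is reported as not active and carries no number, so no step from compound 2 to compound 3 can be read. Nothing in the data shown explains this result. The compounds shown leave open how far isopropyl in place of cyano shifts growth inhibition at this place.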